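The source may report more compounds than this note shows. Statements on the series, on what has been measured and on what is new or still open speak of the compounds shown alone.

In a physicochemical assay for solubility, at pH 7.8 (on this read-out lower numbers stand for lower solubility and higher numbers for higher solubility), the three measured compounds stand as follows:

Compound 1 `O=C(CN1CCN(c2cc3c(cc2F)c(=O)c(C(=O)O)cn3C2CC2)CC1)Nc1ccc(C(=O)/C=C/c2cccc(Cl)c2)cc1`: 29.7 ug/mL
Compound 2 `O=C(CN1CCN(c2cc3c(cc2F)c(=O)c(C(=O)O)cn3C2CC2)CC1)Nc1ccc(C(=O)/C=C/c2ccc(Cl)cc2)cc1`: 2.23 ug/mL
Compound 3 `COc1ccc(/C=C/C(=O)c2ccc(NC(=O)CN3CCN(c4cc5c(cc4F)c(=O)c(C(=O)O)cn5C4CC4)CC3)cc2)cc1OC`: 0.68 ug/mL

Compound 3 holds the lowest number of the three. Its nearest neighbour is compound 2, from which it is reached by a 3.3-fold lower number from compound 2 to compound 3 (0.52 log units; beyond the scatter); the furthest is compound 1, from which it is reached by a 44-fold lower number from compound 1 to compound 3 (1.64 log units; beyond the scatter). The remaining step, a 13-fold lower number from compound 1 to compound 2 (1.12 log units; beyond the scatter), shows how far a move of one chloro around the ring alone can carry this read-out.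

Compound 4 `COc1cc(/C=C/C(=O)c2ccc(NC(=O)CN3CCN(c4cc5c(cc4F)c(=O)c(C(=O)O)cn5C4CC4)CC3)cc2)cc(OC)c1OC` differs from compound 3 by methoxy in place of hydrogen on an aromatic carbon, that is, 3,4-dimethoxyphenyl becomes 3,4,5-trimethoxyphenyl, the new methoxy sitting ortho to a methoxy group, meta to a large group and meta to a methoxy group. All three measured steps change the substituent on that aryl ring, and each lowered the number; the closest in kind, from compound 2 to compound 3, added methoxy groups and was modest. Going by the values given here, no measured pair adds a third methoxy to an already dimethoxylated ring, so the bearing is indirect.

Compound 4 is therefore expected to move by a 1.5-fold lower number from compound 3 to compound 4 (0.18 log units; within the scatter) in this assay, a small downward step that may not exceed the scatter. The estimate for compound 4 is 0.45 ug/mL, with a range from 0.12 ug/mL to 1.6 ug/mL.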

Compound 4, solubility: 2.01 ug/mL
Estimate against measurement, compound 4: 4.5-fold (0.65 log units) below; measured number outside the range, above it.
By their numbers in this assay, from the lowest: compound 3; then compounds 4 and 2 (each within the scatter of the next); then compound 1.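

In this assay, going by these compounds alone, the added methoxy is the first change on this aryl ring that raises the number (a 3.0-fold higher number from compound 3 to compound 4 (0.47 log units; beyond the scatter)), whereas every earlier step on the ring lowered it. With the methoxy ortho to a methoxy group, the 3,4,5-trimethoxyphenyl ring cancels the drop seen on going to 3,4-dimethoxyphenyl and leaves no separation from the 4-chlorophenyl compound (a 1.1-fold lower number from compound 2 to compound 4 (0.05 log units; within the scatter)), while the 3-chlorophenyl compound still stands clearly apart (a 15-fold lower number from compound 1 to compound 4 (1.17 log units; beyond the scatter)). The number of methoxy groups on this ring therefore does not track the read-out in one direction among these compounds: compound 3 falls below compound 2, but compound 4 does not stay below it.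

No available evidence bears on why the number rose at this position. As far as these compounds go, whether the rise belongs to this single methoxy or to the full 3,4,5-trimethoxyphenyl pattern stays open, as does the effect of placing a hydroxyl group or an amine at the same ring carbon.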